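From (oxan-4-yl)methyl to 2-(oxan-4-yl)ethyl

This account rests on a few compounds, and the source may have more. Where it says the series, first, only, none or still open, it means among the compounds named here.

In an ADME assay on the whole organism for pharmacokinetics, with Rattus norvegicus as the target, at a dose of 5 mg/kg by the oral route (a higher number here means more compound in the circulation at the dose given, a lower number less compound in the circulation), compound 2 `Cc1nc(-c2nc[nH]n2)ccc1-c1cnc2c(n1)N(CC1CCOCC1)C(=O)CN2` gives 230 nM, the highest of the three numbers in the series. Compound 1 `Cc1nc(-c2nc[nH]n2)ccc1-c1cnc2c(n1)N([C@H]1CC[C@@H](O)CC1)C(=O)CN2` gives 30 nM, and compound 3 `O=C1CN(CCC2CCOCC2)c2nc(-c3ccc(-c4nc[nH]n4)nc3)cnc2N1` gives 20 nM; both lie well under compound 2.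

The next compound is compound 4 `Cc1nc(-c2nc[nH]n2)ccc1-c1cnc2c(n1)N(CCC1CCOCC1)C(=O)CN2`. The change from compound 2 is (oxan-4-yl)methyl in place of oxan-4-yl on a saturated chain carbon bound to an amide-type nitrogen in a ring. Cut one bond further out, this reads (oxan-4-yl)methyl to 2-(oxan-4-yl)ethyl, on the amide-type nitrogen in a ring.

Among the measured compounds shown here, no measured step covers this exact exchange. For the measured compounds named here, the one step at that nitrogen is a 7.7-fold higher number from compound 1 to compound 2 (0.88 log units; beyond the scatter), a modest step beyond the scatter, but it is a different exchange. Going by the values given here, it shows only that the group at this place can move the number in this assay. The 2-(oxan-4-yl)ethyl group of compound 4 is also carried by compound 3, which gives 20 nM, but the two differ in a further place, so this offers only a weak pointer downward.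

A modest fall is therefore expected, close to the edge of the scatter, with no firm support for a larger one. The expected change is a 2.1-fold lower number from compound 2 to compound 4 (0.32 log units; beyond the scatter). For compound 4 the estimated value is 110 nM, with an expected range of 30 nM to 350 nM.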

Compound 4, maximal plasma concentration: 590 nM
Compound 4: middle estimate off by 5.4-fold (0.73 log units), on the low side, and the stated range ends below it.
By their numbers in this assay, from the lowest: compounds 3 and 1 (each within the scatter of the next); then compound 2; then compound 4.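

In this assay, on the amide-type nitrogen in a ring, going from (oxan-4-yl)methyl to 2-(oxan-4-yl)ethyl gives a 2.6-fold higher number from compound 2 to compound 4 (0.41 log units; beyond the scatter) and shows that one further chain carbon in this group can raise the number beyond the scatter. Measured against the 4-hydroxycyclohexyl group on the same nitrogen, the 2-(oxan-4-yl)ethyl group gives a 20-fold higher number from compound 1 to compound 4 (1.29 log units; beyond the scatter) and turns the modest gain seen earlier at this position into a large one, among compounds that otherwise share the same core. No measurement at hand explains the rise seen with the longer group.

Going by these compounds, whether a longer chain, such as 3-(oxan-4-yl)propyl, would raise the number further or lower it remains open, as does the outcome of an amine such as piperidin-4-yl in place of the oxan-4-yl ring at the end of the chain. The maximal plasma concentration at one oral dose also leaves open how exposure over time, absorption and clearance differ among these compounds.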